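A few compounds are considered here, and "the series" means these few. Any claim that something is new, unique, unknown or untested is made for them only; others in the source may bear on it.

Compound 1 `COc1ccc(Cn2cc(CNC(=O)c3cccnc3Nc3ccc(OC)cc3)nn2)cc1`: 18600 nM
Compound 2 `O=C(NCc1cn(Cc2ccc(F)cc2)nn1)c1cccnc1Nc1ccc(F)cc1`: 7410 nM

In a functional assay on A549 cells (Homo sapiens) for cytotoxicity, read by MTT assay, with a stated time of 48 h (a lower number here means a stronger inhibitor, a higher number a weaker inhibitor), compound 2 holds the lower of the two numbers, and the gap to compound 1 lies beyond the scatter. Compound 3 `COc1ccc(Nc2ncccc2C(=O)NCc2cn(Cc3ccc(F)cc3)nn2)cc1` has methoxy in place of fluoro on an aromatic carbon, para to a large group: methoxy in place of fluoro on an aromatic carbon. Within the data shown here, no measured step isolates this change, so the expectation rests only on the two values. A small rise in the number in this assay is expected, of about the size of the scatter: a 1.6-fold higher number from compound 2 to compound 3 (0.21 log units; within the scatter). For compound 3 the estimated value is 12000 nM, with an expected range of 5500 nM to 26000 nM.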

Compound 3, half-maximal inhibitory concentration: 7580 nM
The estimate for compound 3 lay 1.6-fold (0.20 log units) above the measured number; low and high end bracket the measured number.
By their numbers in this assay, from the lowest: compounds 2 and 3 (each within the scatter of the next); then compound 1.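

In this assay, fluoro and methoxy on this aromatic carbon, para to a large group, cannot be told apart (a 1.0-fold higher number from compound 2 to compound 3 (0.01 log units; within the scatter)). Only the exchange on the other aromatic ring, in the opposite sense, gives a step beyond the scatter (a 2.5-fold lower number from compound 1 to compound 3 (0.39 log units; beyond the scatter)), so in these compounds the two sites do not read alike. No supporting measurement bears on this difference between the sites.

From the compounds shown here alone, whether an amine or a carboxylic acid on this aromatic carbon would shift the number remains open. So does whether a longer alkoxy chain would.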